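This account rests on a few compounds, and the source may have more. Where it says the series, first, only, none or still open, it means among the compounds named here.

Compound 2 `COC(=O)C1=C(C)N(C)C(=O)NC1c1ccoc1` gives the lower of the two numbers recorded so far. For the measured compounds named here, in an assay on membranes from HEK293 cells for displacement of a labelled ligand from adenosine receptor A2b (Homo sapiens), read by scintillation counting, with a stated time of 30 min, tested at 1 uM (on this read-out lower numbers stand for less inhibition and higher numbers for more inhibition at the one concentration tested (going by the name of the read-out)), compound 2 gives 7%, while compound 1 `COC(=O)C1=C(C)N(C)C(=O)NC1c1ccco1` gives 31%; the only recorded step, a number 24 percentage points lower from compound 1 to compound 2 (beyond the scatter), concerns the position of the attachment on the furan ring. Compound 3 `CC1=C(C(=O)OCc2ccccc2)C(c2ccoc2)NC(=O)N1C` differs from compound 2 in a different place: phenyl in place of hydrogen on a saturated chain carbon bound to an oxygen next to a carbonyl group. Going by the values given here, no measured step touches that part of the molecule, so the step on the furan ring offers no guide to what this change will do, and there is nothing in the data to point one way or the other. The safest expectation is therefore a step from compound 2 to compound 3 of a number 5 percentage points higher from compound 2 to compound 3 (within the scatter), none beyond the scatter. Compound 3 is expected to give about 12%, within a range from 0% to 35%.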

Compound 3, a percentage reported as inhibition, at one concentration (the size of the read-out at that concentration, not a potency): 49%
Compound 3: the middle estimate sits 37 percentage points below what was measured; the measured number lies above the stated range.
By their numbers in this assay, from the lowest: compound 2; then compound 1; then compound 3.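

For the compounds shown here, compound 2 and compound 3 carry the same furan-3-yl group and differ only at the ester end, so this is the first measured sign that this end of the molecule matters. In this assay the change from methoxy to benzyloxy, that is, phenyl in place of hydrogen on a saturated chain carbon bound to an oxygen next to a carbonyl group, gives a number 42 percentage points higher from compound 2 to compound 3 (beyond the scatter) and counts as a large step. Nothing measured here accounts for this rise.

The compounds shown leave open whether the aromatic ring itself matters, a question that an ethoxy or cyclohexylmethoxy group in the same place could help to settle. They also leave open how a carboxylic acid there would read, and whether benzyloxy gives a similar rise when paired with furan-2-yl.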